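Bromo in Place of Methyl at a Second Site

The source may report more compounds than this note shows. Statements on the series, on what has been measured and on what is new or still open speak of the compounds shown alone.

Three compounds have been measured in a functional assay on SW1573 cells (Homo sapiens) for inhibition, read by sulforhodamine B assay, with a stated time of 48 h; on this read-out higher numbers stand for weaker inhibition of growth and lower numbers for stronger inhibition of growth:

compound 1, `COC(=O)[C@@]1(C)CCC=C2[C@@H]1CC[C@@H](C)[C@]2(C)Cc1c(C)[nH]c2ccc(C)cc12`, gives 18000 nM
compound 2, `COC(=O)[C@@]1(C)CCC=C2[C@@H]1CC[C@@H](C)[C@]2(C)Cc1c(C)[nH]c2ccc(Br)cc12`, gives 14000 nM
compound 3, `COC(=O)[C@@]1(C)CCC=C2[C@@H]1CC[C@@H](C)[C@]2(C)Cc1c(C)[nH]c2c(C)cccc12`, gives 15000 nM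

Compound 1 and compound 2 share one core and differ in a single place: bromo in place of methyl on an aromatic carbon. That exchange gave the step of a 1.3-fold lower number from compound 1 to compound 2 (0.11 log units; within the scatter), so the two values cannot be told apart. Compound 3 is built from the same atoms as compound 1, joined differently; the difference between the two cores is not broken down here. Its value lies within the scatter of both compound 1 and compound 2, so the three measured numbers sit in one cluster.

Compound 4, `COC(=O)[C@@]1(C)CCC=C2[C@@H]1CC[C@@H](C)[C@]2(C)Cc1c(C)[nH]c2c(Br)cccc12`, has not yet been measured. It stands to compound 3 as compound 2 stands to compound 1: bromo in place of methyl on an aromatic carbon. Among the measured compounds shown here, this is the same kind of change as the one from compound 1 to compound 2, not the same one, since the place is different: in compound 2 the bromo sits meta to a fused ring and para to a fused ring, while in compound 4 it sits ortho to a fused ring and meta to a fused ring.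

For the measured compounds named here, the only measured example of this kind of change, a 1.3-fold lower number from compound 1 to compound 2 (0.11 log units; within the scatter), stayed within the scatter. Compound 4 is therefore expected to land close to the three measured values, with an expected step of a 1.3-fold lower number from compound 3 to compound 4 (0.10 log units; within the scatter). In this assay compound 4 is estimated at 12000 nM, most likely between 6000 nM and 25000 nM.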

Compound 4, concentration for 50% growth inhibition: 25000 nM
The estimate for compound 4 lay 2.1-fold (0.32 log units) below the measured number; the measured number falls inside the stated range.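

In this assay, bromo in place of methyl at the second site gave a 1.7-fold higher number from compound 3 to compound 4 (0.22 log units; within the scatter), so compound 3 and compound 4 cannot be told apart, just as compound 1 and compound 2 could not. Set side by side, the two results for this exchange do not differ by more than repeated measurements of this kind would be expected to: the same change on two cores in this assay, a 1.3-fold lower number (0.11 log units; within the scatter) from compound 1 to compound 2 and a 1.7-fold higher number (0.22 log units; within the scatter) from compound 3 to compound 4, 2.1-fold (0.33 log units) apart, within the scatter of two such steps On these two cores and at these two places, then, swapping methyl for bromo produced no step that can be distinguished from the scatter; this does not show that the two groups are interchangeable across the series, and any small real effect of the exchange could stay hidden inside the scatter of only two pairs.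

On these data alone, all four compounds carry either methyl or bromo on the six-membered aromatic ring, so it remains open whether a different group there, such as an amine, a carboxylic acid or a longer chain, would move the number beyond the scatter. The methyl ester is also the same in all four compounds, which leaves open what a carboxylic acid or an amide in its place would do to the growth-inhibition number.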